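The compounds below may be only part of what the source reports. "The series", "measured", "known", "first", "only" and "open" are said of these compounds alone.

Measured so far in an assay on brain for inhibition of Fatty-acid amide hydrolase 1 (Rattus norvegicus), read by scintillation counting, with a stated time of 10 min; a lower number here means a stronger inhibitor, a higher number a weaker inhibitor:
compound 1, `CC(C)Cc1ccc(C(C)C(=O)N2CCN(c3ccccc3)CC2)cc1`: 4700 nM
compound 2, `CC(C)Cc1ccc(C(C)C(=O)N2CCN(c3cccc(Cl)c3)CC2)cc1`: 1700 nM
compound 3, `COc1ccc(N2CCN(C(=O)C(C)c3ccc(CC(C)C)cc3)CC2)cc1`: 4500 nM

Compound 3 stands second highest of these three numbers. Its value and that of compound 1 lie within the scatter of each other, while the step of a 2.6-fold higher number from compound 2 to compound 3 (0.42 log units; beyond the scatter) lies beyond it. Compound 4, `Cc1cccc(N2CCN(C(=O)C(C)c3ccc(CC(C)C)cc3)CC2)c1`, differs from compound 3 in one place: 3-methylphenyl in place of 4-methoxyphenyl on an amine nitrogen in a ring. The measured steps that bear on this swap of the aryl group on the ring nitrogen are a 2.8-fold lower number from compound 1 to compound 2 (0.44 log units; beyond the scatter), a modest lowering, and a 1.0-fold lower number from compound 1 to compound 3 (0.02 log units; within the scatter), no change. If the methyl group follows the chloro pattern rather than the methoxy pattern, a modest lowering is expected, a 1.8-fold lower number from compound 3 to compound 4 (0.26 log units; within the scatter). Compound 4 is therefore estimated at 2500 nM, with a range from 1000 nM to 6000 nM.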

Compound 4, half-maximal inhibitory concentration: 16000 nM
The estimate for compound 4 lay 6.4-fold (0.81 log units) below the measured number; measured number outside the range, above it.
By their numbers in this assay, from the lowest: compound 2; then compounds 3 and 1 (each within the scatter of the next); then compound 4.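

Among these compounds, compound 4 is the first case here in which a group on the aromatic ring raises the number relative to the hydrogen of compound 1 (a 3.4-fold higher number from compound 1 to compound 4 (0.53 log units; beyond the scatter)), so a change at this ring can weaken as well as strengthen inhibition. Methyl and chloro, though similar in being single small groups, give clearly different results as 3-methylphenyl and 3-chlorophenyl (a 9.4-fold higher number from compound 2 to compound 4 (0.97 log units; beyond the scatter)), and replacing 4-methoxyphenyl with 3-methylphenyl also raises the number (a 3.6-fold higher number from compound 3 to compound 4 (0.55 log units; beyond the scatter)). Nothing available explains these differences.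

The compounds shown leave open where other groups on this ring, such as fluoro or nitrile, would fall. They also leave open how 4-methylphenyl or 3-methoxyphenyl would compare, which would separate the effect of the group from that of its place.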